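The source may report more compounds than this note shows. Statements on the series, on what has been measured and on what is new or still open speak of the compounds shown alone.

Working notes on the series. In a functional assay on A549 cells (Homo sapiens) for cytotoxicity, read by MTT assay, with a stated time of 72 h (a lower number here means a stronger inhibitor, a higher number a weaker inhibitor), compound 1 `CNC(=O)c1cc(Oc2ccc(C(=O)/C=C/c3ccco3)cc2)ccn1` gives "not determined" (no result reported), and compound 2 `CNC(=O)c1cc(Oc2ccc(C(=O)/C=C/c3cccc(Br)c3)cc2)ccn1` gives 9940 nM. Compound 3 `CNC(=O)c1cc(Oc2ccc(C(=O)/C=C/c3ccc(Br)cc3)cc2)ccn1` stands at > 50000 nM, which is a limit and not a number. Compound 4 `CNC(=O)c1cc(Oc2ccc(C(=O)/C=C/c3ccc(F)cc3Cl)cc2)ccn1` differs from it by 2-chloro-4-fluorophenyl in place of 4-bromophenyl on a double-bonded chain carbon bound to a double-bonded chain carbon, with 2-chloro-4-fluorophenyl in place of 4-bromophenyl. Among the compounds with values here, the one measured step at this place is an at least 5.0-fold higher number from compound 2 to compound 3 (0.70 log units; beyond the scatter), so exchanging this group can shift the value beyond the scatter. Within the data shown here, that single step is the only guide to size, and a shift towards a lower number is expected, of no more than a similar size. The expected change is an at least 1.7-fold lower number from compound 3 to compound 4 (0.25 log units; that floor lies within the scatter). The estimate for compound 4 is 28000 nM, with an expected range of 8000 nM to 70000 nM.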

Compound 4, half-maximal inhibitory concentration: 21100 nM
Beside the measured number, compound 4's estimate is 1.3-fold (0.12 log units) above it, within the range that was stated.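

Replacing 4-bromophenyl with 2-chloro-4-fluorophenyl at this place brings a measurable value in this assay, with an at least 2.3-fold lower number from compound 3 to compound 4 (0.37 log units; beyond the scatter), yet the 3-bromophenyl compound keeps the lower number, with a 2.1-fold higher number from compound 2 to compound 4 (0.33 log units; beyond the scatter). The first of these steps has no fixed size because it starts from a limit: the limit of > 50000 nM in this assay, at which 1 of the 4 values shown sits.

The compounds shown change chlorine and fluorine together, so 2-chlorophenyl and 4-fluorophenyl alone remain open as separate comparisons. From the compounds shown here alone, the effect of an amine or a carboxylic acid on this phenyl ring also remains open.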